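The source may report more compounds than this note shows. Statements on the series, on what has been measured and on what is new or still open speak of the compounds shown alone.

Among the measured compounds shown here, compound 3 `CCN(CC)c1nc(Nc2ccc(C(F)(F)F)cc2)c2nc(Nc3c(Cl)cccc3Cl)sc2n1` gives 48 nM in a functional assay on HEK293 cells for antagonist activity at transient receptor potential cation channel subfamily V member 1 (Homo sapiens), read by calcium flux (on this read-out higher numbers stand for weaker inhibition and lower numbers for stronger inhibition), the second highest of the three numbers so far: compound 1 `FC(F)(F)c1ccc(Nc2nc(N3CCCC3)nc3sc(Nc4c(Cl)cccc4Cl)nc23)cc1` gives 12 nM and compound 2 `FC(F)(F)c1ccc(Nc2nc(N3CCNCC3)nc3sc(Nc4c(Cl)cccc4Cl)nc23)cc1` gives 5000 nM. Compound 4 `CC(C)Nc1nc(Nc2ccc(C(F)(F)F)cc2)c2nc(Nc3c(Cl)cccc3Cl)sc2n1` differs from compound 3 by isopropylamino in place of diethylamino on an aromatic carbon. For the measured compounds named here, two measured steps bear on this position. The closest is a 4.0-fold higher number from compound 1 to compound 3 (0.60 log units; beyond the scatter), a modest rise between two amines on this carbon. The other is a 420-fold higher number from compound 1 to compound 2 (2.62 log units; beyond the scatter), where the entering amine also carried a hydrogen-bond donor and the rise was large. Some loss in this assay is therefore expected, probably modest rather than large, since the entering group here is smaller than the leaving one. The expected step is a 3.1-fold higher number from compound 3 to compound 4 (0.49 log units; beyond the scatter). Compound 4 is thus estimated at 150 nM, within a range of 40 nM to 600 nM.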

Compound 4, half-maximal inhibitory concentration: 13 nM
The estimate for compound 4 lay 12-fold (1.06 log units) above the measured number; the measured number lies below the stated range.
By their numbers in this assay, from the lowest: compounds 1 and 4 (each within the scatter of the next); then compound 3; then compound 2.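

In this assay, a 3.7-fold lower number from compound 3 to compound 4 (0.57 log units; beyond the scatter) shows that an amine carrying a hydrogen-bond donor on this carbon can give a lower number, so the donor alone does not account for the high number of compound 2, as a 380-fold lower number from compound 2 to compound 4 (2.59 log units; beyond the scatter) also shows. With a 1.1-fold higher number from compound 1 to compound 4 (0.03 log units; within the scatter), the open-chain isopropylamino group stands level with pyrrolidin-1-yl, so no ring is needed here for a low number. No measurement at hand accounts for these steps.

Still open, on these data alone, is whether methylamino or cyclopropylamino would keep this level, and whether morpholin-4-yl would behave like pyrrolidin-1-yl or piperazin-1-yl.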